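Compound 4: a 2-Chlorophenyl Replaces the Trifluoromethylphenyl

A few compounds are considered here, and "the series" means these few. Any claim that something is new, unique, unknown or untested is made for them only; others in the source may bear on it.

Compound 3 `COc1nc(-c2ccc(C(F)(F)F)cc2)ccc1[C@@H](c1ccccc1)[C@@](O)(CCN(C)C)c1cccc2ccccc12` is one of three analogues measured in a toxicity assay on Vero cells (Chlorocebus sabaeus) for cytotoxicity; a lower number here means that less compound is tolerated, a higher number that more compound is tolerated. In this assay compound 3 gives > 50 ug/mL, which is a limit of the assay rather than a number. Compound 1 `COc1nc(-c2ccc(C#N)cc2)ccc1[C@@H](c1ccccc1)[C@@](O)(CCN(C)C)c1cccc2ccccc12` gives > 50 ug/mL, likewise a limit. Compound 2 `COc1nc(-c2cccc(Cl)c2)ccc1[C@@H](c1ccccc1)[C@@](O)(CCN(C)C)c1cccc2ccccc12` gives > 50 ug/mL, again a limit. Because (the limit of > 50 ug/mL in this assay, at which 3 of the 3 values shown sit), the steps a step that the two limits leave unreadable from compound 1 to compound 2, a step that the two limits leave unreadable from compound 1 to compound 3 and a step that the two limits leave unreadable from compound 2 to compound 3 cannot be read. Compound 4 `COc1nc(-c2ccccc2Cl)ccc1[C@@H](c1ccccc1)[C@@](O)(CCN(C)C)c1cccc2ccccc12` differs from compound 3 by 2-chlorophenyl in place of 4-(trifluoromethyl)phenyl on an aromatic carbon. Within the data shown here, none of the measured steps offers a readable size, so no movement beyond the scatter can be expected for compound 4 in this assay. Compound 4 is therefore expected to sit at the same limit, estimated at 50 ug/mL (range 30 ug/mL to 100 ug/mL), a step of a number no higher from compound 3 to compound 4 (the limit leaves the size open).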

Compound 4, half-maximal cytotoxic concentration: > 50 ug/mL
Compound 4: a limit, no number (the forecaster's own chance of this, stated with the estimate: 80%); the middle value lies on the limit itself.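

In this assay, among these compounds, compound 4 gives > 50 ug/mL as a limit and not a number, so no step linking it to compound 1, compound 2 or compound 3 can be read: the limit of > 50 ug/mL in this assay, at which 4 of the 4 values shown sit. The compounds shown leave open whether these four differ at all in how much compound is tolerated beyond this limit.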